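The source may hold more compounds than are shown below. What is called first, only, known or untested is meant among the compounds shown, and "the series" means these compounds.

Compound 1 `Cn1cc(SCC(=O)Nc2ccccc2Cl)c2ccccc21`: in an ADME assay on HEK-293T cells (Homo sapiens) for cytotoxicity, read by CCK-8 assay, with a stated time of 48 h (on this read-out higher numbers stand for lower toxicity in this test and lower numbers for higher toxicity in this test), compound 1 gives > 100000 nM, a limit of the assay.
Compound 2 `Cn1cc(SCC(=O)Nc2ccc(Cl)c(Cl)c2)c2ccccc21`: in this assay compound 2 gives > 100000 nM, also a limit.
Compound 3 `Cn1cc(SCC(=O)Nc2ccc(Cl)cc2)c2ccccc21`: in this assay compound 3 gives > 100000 nM, again a limit.

Compound 3 therefore stands at the assay limit, and since all three values sit there (the limit of > 100000 nM in this assay, at which 3 of the 3 values shown sit), no order among the three can be read. Compound 4 `Cn1cc(SCC(=O)Nc2ccc(Cl)cc2Cl)c2ccccc21` differs from compound 3 by chloro in place of hydrogen on an aromatic carbon. Two measured steps lead into compound 3, a step that the two limits leave unreadable from compound 1 to compound 3 and a step that the two limits leave unreadable from compound 2 to compound 3, but both run between limits, so their size is not readable and they give no measured direction for adding a chloro group. On this basis compound 4 is expected to sit at 120000 nM, between 50000 nM and 300000 nM. The step that the limit leaves unreadable from compound 3 to compound 4 is thus expected to stay within the scatter, most likely reported only as a limit.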

Compound 4, half-maximal cytotoxic concentration: > 100000 nM
Compound 4: a limit, no number (the forecaster's own chance of this, stated with the estimate: 85%); the middle value lies beyond the limit too.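

Compound 4 is also a limit, so the steps from compound 3 and from compound 1 to compound 4 cannot be read, as all the values shown are limits: the limit of > 100000 nM in this assay, at which 4 of the 4 values shown sit. The compounds shown leave open how compound 1, compound 2, compound 3 and compound 4 rank in this assay against one another.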